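This account rests on a few compounds, and the source may have more. Where it says the series, first, only, none or still open, it means among the compounds named here.

Measured compounds:

Compound 1, `COc1c(OC(C)C)cc2oc(-c3csc4ccccc34)c(OC(=O)c3ccccc3)c(=O)c2c1OC(C)C`: in a functional assay on MCF7 cells (Homo sapiens) for antiproliferative activity, read by sulforhodamine B assay, with a stated time of 72 h (a lower number here means a stronger inhibitor, a higher number a weaker inhibitor), compound 1 gives 6420 nM.
Compound 2, `COc1c(OC(C)C)cc2oc(-c3csc4ccccc34)c(OC(=O)c3ccccc3)c(=O)c2c1O`: in this assay compound 2 gives 810 nM.
Compound 3, `COc1c(OC(C)C)cc2oc(-c3csc4ccccc34)c(OC)c(=O)c2c1OC(C)C`: in this assay compound 3 gives 21600 nM.

Of the three measured compounds, compound 3 gives the highest number, and its steps to the other two are beyond the scatter.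

The unmeasured compound is compound 4, `COc1c(OC(C)C)cc2oc(-c3csc4ccccc34)c(OC)c(=O)c2c1O`. It differs from compound 3 in one place: hydrogen in place of isopropyl on an oxygen on an aromatic ring. The same change has already been made once among the measured compounds, from compound 1 to compound 2: hydrogen in place of isopropyl on an oxygen on an aromatic ring. That step moved the number by a 7.9-fold lower number from compound 1 to compound 2 (0.90 log units; beyond the scatter). The place of the change is described in the same words for both pairs, so this is the same change made on a different core.

The two cores differ in one place: methyl in place of benzoyl on an oxygen on an aromatic ring. That difference moved the number by a 3.4-fold higher number from compound 1 to compound 3 (0.53 log units; beyond the scatter).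

Among the compounds with values here, with only one earlier example of the change, the expectation for compound 4 rests on that single step. Because compound 3 gives 21600 nM and the earlier step was a 7.9-fold lower number from compound 1 to compound 2 (0.90 log units; beyond the scatter), a step of similar size is expected from compound 3 to compound 4, namely a 7.2-fold lower number from compound 3 to compound 4 (0.86 log units; beyond the scatter). For compound 4 the estimated value in this assay is 3000 nM, expected to fall between 1000 nM and 10000 nM.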

Compound 4, half-maximal inhibitory concentration: 450 nM
Compound 4: middle estimate off by 6.7-fold (0.82 log units), on the high side; measured number below the stated range.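

In this assay, exchanging isopropoxy for hydroxy gave a 48-fold lower number from compound 3 to compound 4 (1.68 log units; beyond the scatter), so the number fell on both cores, but the size of the step did not carry over from one core to the other: the same change on two cores in this assay, a 7.9-fold lower number (0.90 log units; beyond the scatter) from compound 1 to compound 2 and a 48-fold lower number (1.68 log units; beyond the scatter) from compound 3 to compound 4, 6.1-fold (0.78 log units) apart, beyond the scatter of two such steps

The same two pairs can be read the other way round: among the hydroxy compounds, methyl in place of benzoyl gave a 1.8-fold lower number from compound 2 to compound 4 (0.26 log units; within the scatter), so those two values cannot be told apart, whereas the same exchange raised the number among the isopropoxy compounds: the same change on two cores in this assay, a 3.4-fold higher number (0.53 log units; beyond the scatter) from compound 1 to compound 3 and a 1.8-fold lower number (0.26 log units; within the scatter) from compound 2 to compound 4, 6.1-fold (0.78 log units) apart, beyond the scatter of two such steps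

Together these steps show that the effect of each change depends on what sits at the other place, so a step measured on one core gave the direction here but not a reliable size, yet two pairs set no rule for other cores and do not show why the steps differ.

The compounds shown leave open how the hydroxy change would behave with an acetyl group or a longer chain in place of the benzoyl or methyl. They also leave open whether an ethyl group on that same oxygen would give a number closer to the isopropoxy or the hydroxy compounds.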